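Swapping the Methoxypyridine on the Sulfonyl for a Methylpyridine

The compounds below may be only part of what the source reports. "The series", "measured", "known", "first", "only" and "open" are said of these compounds alone.

Three measured compounds share one core and differ only in the aromatic ring attached to the sulfonyl sulfur. In a physicochemical assay for lipophilicity, read by HPLC, at pH 7.4 (a higher number here means a more lipophilic compound, a lower number a more polar compound), compound 1 `CNCc1cn(S(=O)(=O)c2cccc(OC)n2)c(-c2cccnc2F)c1F` gives 1.03, which places it second highest of the three numbers. Compound 2 `CNCc1cn(S(=O)(=O)c2cccc(F)n2)c(-c2cccnc2F)c1F` gives 0.7 in this assay, and the step is a number 0.33 log units lower from compound 1 to compound 2 (beyond the scatter). Compound 3 `CNCc1cn(S(=O)(=O)c2cncc(Cl)c2)c(-c2cccnc2F)c1F` gives 1.44, the highest of the three; the step is a number 0.41 log units higher from compound 1 to compound 3 (beyond the scatter), while from the fluoro analogue the step is a number 0.74 log units higher from compound 2 to compound 3 (beyond the scatter).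

Compound 4 `CNCc1cn(S(=O)(=O)c2cncc(C)c2)c(-c2cccnc2F)c1F` is the unmeasured member of the set. Compared with compound 1 it carries 5-methylpyridin-3-yl in place of 6-methoxypyridin-2-yl on a sulfonyl sulfur. Among the measured compounds shown here, the step that bears most on this change is the one from compound 1 to compound 3, where a 5-chloropyridin-3-yl also replaced the 6-methoxypyridin-2-yl and gave a number 0.41 log units higher from compound 1 to compound 3 (beyond the scatter). Compound 4 carries a 5-methylpyridin-3-yl rather than a 5-chloropyridin-3-yl, so a rise is expected, though smaller than that of compound 3, estimated as a number 0.17 log units higher from compound 1 to compound 4 (within the scatter), possibly within the scatter. For compound 4 the value in this assay is therefore estimated at 1.2, with a range from 0.85 to 1.55.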

Compound 4, distribution coefficient: 0.61
Compound 4: middle estimate off by 0.59 log units, on the high side; the measured number lies below the stated range.
By their numbers in this assay, from the lowest: compounds 4 and 2 (each within the scatter of the next); then compound 1; then compound 3.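

At this place, on a sulfonyl sulfur, a small change to the new ring matters a great deal: methyl in place of chloro on an aromatic carbon gives a number 0.83 log units lower from compound 3 to compound 4 (beyond the scatter) in this assay and so separates two compounds that share the same ring. Compound 3 had suggested that leaving the 6-methoxypyridin-2-yl for this kind of ring raises the number, yet the 5-methylpyridin-3-yl gives a number 0.42 log units lower from compound 1 to compound 4 (beyond the scatter) and so goes against that reading, which means the direction of this swap depends on the group the new ring carries. The new ring also gives a number 0.09 log units lower from compound 2 to compound 4 (within the scatter) and so cannot be told apart from the 6-fluoropyridin-2-yl in this measurement, even though the two rings differ in both their group and their point of attachment.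

Nothing among the data shown explains why the methyl and chloro compounds lie so far apart.

On these data alone, with only compound 3 and compound 4 carrying this ring, it remains open where a nitrile, an amine or a methoxy in the same place would fall. As far as these compounds go, it also remains open whether a methyl on the pyridin-2-yl ring of compound 1 would give a similar number.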